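The compounds below may be only part of what the source reports. "The series", "measured", "known", "first", "only" and "open" are said of these compounds alone.

Compound 1 `Cc1cc(O)ccc1C1=NN(c2ccc(S(C)(=O)=O)cc2)C(=O)CC1` is the starting point of this comparison. For the measured compounds named here, in a functional assay on the whole organism (strain Wistar) for inhibition, with Rattus norvegicus as the target, read by paw edema, with stated times of 30 min and 3 h, at a dose of 0.05 mmol/kg by the oral route (a lower number here means less inhibition, a higher number more inhibition at the dose given (going by the name of the read-out)), compound 1 gives 33.3%, the lowest of the three numbers measured so far; compound 2 `CCc1ccc(C2=NN(c3ccc(S(C)(=O)=O)cc3)C(=O)CC2)cc1` gives 46.7% and compound 3 `CC(C)(C)c1ccc(C2=NN(c3ccc(S(C)(=O)=O)cc3)C(=O)CC2)cc1` gives 50%. The two measured steps both alter the group that sits on the carbon with a double bond to nitrogen in the shared core, or a substituent on that group. The step of a number 13.4 percentage points higher from compound 1 to compound 2 (beyond the scatter) lies beyond the scatter, whereas the step of a number 3.3 percentage points higher from compound 2 to compound 3 (within the scatter) stays within it.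

Compound 4 `CS(=O)(=O)c1ccc(N2N=C(c3ccc(F)cc3)CCC2=O)cc1` has not yet been measured. It differs from compound 1 in one place: 4-fluorophenyl in place of 4-hydroxy-2-methylphenyl on a carbon with a double bond to nitrogen. Going by the values given here, this change resembles the one from compound 1 to compound 2, where the same 4-hydroxy-2-methylphenyl left and a phenyl carrying a single small group entered, and that change brought a modest rise. Because a number 13.4 percentage points higher from compound 1 to compound 2 (beyond the scatter) was beyond the scatter, a rise of similar size is expected here, although a different entering group makes the exact size uncertain. Compound 4 is therefore estimated at 45%, with a likely range from 30% to 60%. This estimate amounts to an expected a number 11.7 percentage points higher from compound 1 to compound 4 (beyond the scatter).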

Compound 4, a percentage reported as inhibition, in the whole organism at one dose (the size of the read-out at that dose, not a potency): 60%
Beside the measured number, compound 4's estimate is 15 percentage points below it, and the stated range covers the measured number.
By their numbers in this assay, from the lowest: compound 1; then compounds 2, 3 and 4 (each within the scatter of the next, the first and the last beyond it).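

Replacing 4-hydroxy-2-methylphenyl with 4-fluorophenyl on the carbon with a double bond to nitrogen gives a number 26.7 percentage points higher from compound 1 to compound 4 (beyond the scatter) in this assay, so a clear rise here does not depend on an alkyl group, the only kind of substituent on the entering phenyl in the earlier step. The substituent on the aromatic carbon can also matter: fluoro in place of ethyl gives a number 13.3 percentage points higher from compound 2 to compound 4 (beyond the scatter), a difference the earlier comparison of ethyl with tert-butyl did not show. Fluoro in place of tert-butyl, however, gives a number 10 percentage points higher from compound 3 to compound 4 (within the scatter), so these three groups form no clean ranking: the ethyl and fluoro compounds can be told apart, but the tert-butyl compound cannot be separated from either.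

Compound 1 differs from the others by both a hydroxy and a methyl group, so the compounds shown leave open which of the two matters, and how a chloro, a methoxy or an amine on the same aromatic carbon would compare. Nothing available here explains the size of these steps.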